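Ester, amide and thioester variation on the carbonyl carbon

The source may report more compounds than this note shows. Statements on the series, on what has been measured and on what is new or still open speak of the compounds shown alone.

The series shares one core, seen in compound 1 `COC(=O)C1=C(C)NC(=O)NC1c1cccs1`, compound 2 `CC1=C(C(=O)NC(C)C)C(c2cccs2)NC(=O)N1` and compound 3 `CC1=C(C(=O)SC(C)C)C(c2cccs2)NC(=O)N1`, and differs only in the group on the carbonyl carbon. In an assay on membranes from HeLa cells for displacement of a labelled ligand from adenosine receptor A3 (Homo sapiens), read by scintillation counting, with a stated time of 180 min, tested at 1 uM (a higher number here means more inhibition at the concentration tested (going by the name of the read-out), a lower number less inhibition), compound 1 gives 3%, compound 2 gives 1% and compound 3 gives 1%. Compound 3 therefore stands level with compound 2 at the digits reported, the two together forming the lowest pair of the three numbers; its furthest neighbour is compound 1, and that gap is a number 2 percentage points lower from compound 1 to compound 3 (within the scatter), which stays within the scatter, as does a number 2 percentage points lower from compound 1 to compound 2 (within the scatter) and no change at the digits printed from compound 2 to compound 3 (within the scatter).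

Compound 4 `CC1=C(C(=O)OCC2CC2)C(c2cccs2)NC(=O)N1` is not yet measured. Relative to compound 3 the change is cyclopropylmethoxy in place of isopropylsulfanyl on a carbonyl carbon. The measured steps that bear on it are the three exchanges on the same carbonyl carbon, every one within the scatter, so methoxy, isopropylamino and isopropylsulfanyl have all behaved alike here. Cyclopropylmethoxy returns to an oxygen-linked group, as in compound 1, and nothing in these numbers points to a step beyond the scatter in this assay. Compound 4 is therefore expected at 2%, with a range of -6% to 10%. The expected step is a number 1 percentage points higher from compound 3 to compound 4 (within the scatter), flat within the scatter.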

Compound 4, a percentage reported as inhibition, at one concentration (the size of the read-out at that concentration, not a potency): 1%
Beside the measured number, compound 4's estimate is 1 percentage points above it, within the range that was stated.
By their numbers in this assay, from the lowest: compounds 2, 3, 4 and 1 (each within the scatter of the next).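

Cyclopropylmethoxy puts a ring into the group on the carbonyl carbon for the first time in this series, yet in this assay the exchange for isopropylsulfanyl gives no change at the digits printed from compound 3 to compound 4 (within the scatter) and the exchange for isopropylamino gives no change at the digits printed from compound 2 to compound 4 (within the scatter) in this comparison. Against methoxy, the other oxygen-linked group, cyclopropyl in place of hydrogen on a saturated chain carbon bound to an oxygen next to a carbonyl group gives a number 2 percentage points lower from compound 1 to compound 4 (within the scatter) as its step, so adding the three-membered ring to that chain carbon leaves the read-out flat. All four groups at this position now lie within the scatter of one another at the single concentration tested, and no measurement shown accounts for this flat result.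

The compounds shown leave open whether any group on this carbonyl carbon can move the number beyond the scatter, for example a benzyloxy group, a longer chain such as hexyloxy, or a free carboxylic acid. They also leave open whether a change elsewhere on the shared core would give a number that such exchanges could then shift.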